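This account rests on a few compounds, and the source may have more. Where it says the series, first, only, none or still open, it means among the compounds named here.

Working notes on a series sharing one core. Compound 3 `Cc1ccc(C(=O)/C=C/c2ccc3c(c2)B(O)OC3)cc1` gives the lowest of the three numbers in a functional assay on SK-OV-3 cells (Homo sapiens) for cytotoxicity, read by MTT assay, with a stated time of 48 h (a higher number here means a weaker inhibitor, a lower number a stronger inhibitor), with compound 3 at 3700 nM. Compound 1 `O=C(/C=C/c1ccc2c(c1)B(O)OC2)c1ccco1` gives 20700 nM in this assay, and compound 2 `Cn1cccc1C(=O)/C=C/c1ccc2c(c1)B(O)OC2` gives 93600 nM. Every measured step exchanges the whole group on the carbonyl carbon: a 5.6-fold lower number from compound 1 to compound 3 (0.75 log units; beyond the scatter), a 25-fold lower number from compound 2 to compound 3 (1.40 log units; beyond the scatter) and a 4.5-fold higher number from compound 1 to compound 2 (0.66 log units; beyond the scatter). Compound 4 `O=C(/C=C/c1ccc2c(c1)B(O)OC2)c1ccc([N+](=O)[O-])cc1` differs from compound 3 by nitro in place of methyl on an aromatic carbon. Going by the values given here, no measured step changes a substituent on that six-membered aromatic ring of carbon only, so none bears directly; the measured steps only show that the group on the carbonyl carbon moves the number by modest to large amounts. The expected step of a 1.4-fold higher number from compound 3 to compound 4 (0.13 log units; within the scatter) is therefore small and uncertain. Compound 4 is estimated at 5000 nM, with a range of 1500 nM to 20000 nM.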

Compound 4, half-maximal inhibitory concentration: 7900 nM
The estimate for compound 4 lay 1.6-fold (0.20 log units) below the measured number, within the range that was stated.
By their numbers in this assay, from the lowest: compound 3; then compound 4; then compound 1; then compound 2.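

Going by these compounds alone, this is the first step that changes only a substituent on the six-membered aromatic ring of carbon only, leaving the rest of the molecule untouched: in this assay, nitro in place of methyl gives a 2.1-fold higher number from compound 3 to compound 4 (0.33 log units; beyond the scatter). That step is smaller than those that exchange the whole group on the carbonyl carbon, such as a 25-fold lower number from compound 2 to compound 3 (1.40 log units; beyond the scatter). No data on hand give a reason for the step. Going by these compounds, how an amine or a carboxylic acid at this place would compare with methyl and nitro stays open, as does whether this step keeps its size with a furan-2-yl or 1-methyl-1H-pyrrol-2-yl group on the carbonyl carbon.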